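Isobutoxy Replaces the Acetamidoethyl Chain on the Amide

The compounds below may be only part of what the source reports. "The series", "measured", "known", "first", "only" and "open" are said of these compounds alone.

Among the compounds with values here, compound 2 `CC(=O)NCCNC(=O)[C@H]1OC(n2cnc3c(N)ncnc32)[C@H](O)[C@@H]1O` gives 46 nM in an assay on cell membranes for binding affinity to 2-oxoglutarate receptor 1 (Rattus norvegicus), read by radioligand binding (a higher number here means a weaker inhibitor, a lower number a stronger inhibitor), the highest of the two numbers measured so far. Within the data shown here, its nearest neighbour, compound 1 `CCCCNC(=O)[C@H]1OC(n2cnc3c(N)ncnc32)[C@H](O)[C@@H]1O`, gives 17 nM in this assay, and the single measured step, a 2.7-fold higher number from compound 1 to compound 2 (0.43 log units; beyond the scatter), went with exchanging a plain alkyl end for a chain bearing an acetamido group. Compound 3 `CC(C)CONC(=O)[C@H]1OC(n2cnc3c(N)ncnc32)[C@H](O)[C@@H]1O` has not yet been measured; it differs from compound 2 by isobutoxy in place of 2-acetamidoethyl on an amide-type nitrogen. Among the measured compounds shown here, the one step that bears on this, a 2.7-fold higher number from compound 1 to compound 2 (0.43 log units; beyond the scatter), is modest, and compound 3 again carries a branched alkyl end without the acetamido group, although its link through an oxygen is new among the measured compounds, so the direction rests on thin ground. Compound 3 is therefore expected to give about 25 nM in this assay, within 8 nM to 80 nM. The expected step is a 1.8-fold lower number from compound 2 to compound 3 (0.26 log units; within the scatter), a modest move downward.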

Compound 3, inhibition constant: 20 nM
Beside the measured number, compound 3's estimate is 1.3-fold (0.10 log units) above it; measured number inside the range.
By their numbers in this assay, from the lowest: compounds 1 and 3 (each within the scatter of the next); then compound 2.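

In this assay, isobutoxy in place of 2-acetamidoethyl on the amide-type nitrogen gives a 2.3-fold lower number from compound 2 to compound 3 (0.36 log units; beyond the scatter), so a second chain end without the acetamido group also has a lower number than compound 2. Isobutoxy in place of butyl gives a 1.2-fold higher number from compound 1 to compound 3 (0.07 log units; within the scatter), which means that this change, unlike the two involving 2-acetamidoethyl, does not separate the compounds beyond the usual scatter. No measurement here explains these differences in the numbers.

The compounds shown leave open how a longer chain, or a chain ending in an amine or a carboxylic acid, would read on this nitrogen. Butyl and isobutoxy also differ in both the oxygen link and the branching, so butoxy and isobutyl would be the groups to separate these two features.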